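One Added Chain Carbon in Two Related Series

This account rests on a few compounds, and the source may have more. Where it says the series, first, only, none or still open, it means among the compounds named here.

Compound 1 `CN(C)CCNc1nc(N/N=C/c2ccc(F)cc2)nc2ccccc12` and compound 2 `CN(C)CCCNc1nc(N/N=C/c2ccc(F)cc2)nc2ccccc12` share a core and differ only by (dimethylamino)methyl in place of dimethylamino on a saturated chain carbon, two bonds along the chain from a nitrogen on an aromatic ring. In a functional assay on HT-29 cells (Homo sapiens) for cytotoxicity, read by MTT assay, with a stated time of 72 h (a higher number here means a weaker inhibitor, a lower number a stronger inhibitor), compound 1 gives 1530 nM, while compound 2 gives 870 nM, a step of a 1.8-fold lower number from compound 1 to compound 2 (0.25 log units; within the scatter). Compound 3 `CN(C)CCNc1nc(N/N=C/c2nccn2Cc2ccccc2)nc2ccccc12` carries a different core; how that core differs from the core of compound 1 is not broken down here. In this assay compound 3 gives 2620 nM. Compound 4 `CN(C)CCCNc1nc(N/N=C/c2nccn2Cc2ccccc2)nc2ccccc12` has not yet been measured and differs from compound 3 by the same change, ((dimethylamino)methyl in place of dimethylamino on a saturated chain carbon, two bonds along the chain from a nitrogen on an aromatic ring). Because the earlier step was a 1.8-fold lower number from compound 1 to compound 2 (0.25 log units; within the scatter), a step of similar size, a 1.7-fold lower number from compound 3 to compound 4 (0.24 log units; within the scatter), is expected here, though the earlier step itself sat within the scatter. In this assay compound 4 is therefore estimated at 1500 nM, with a likely range from 700 nM to 3200 nM.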

Compound 4, half-maximal inhibitory concentration: 1980 nM
Compound 4: the middle estimate sits 1.3-fold (0.12 log units) below what was measured; measured number inside the range.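

In this assay the same change on the core of compound 3 comes to a 1.3-fold lower number from compound 3 to compound 4 (0.12 log units; within the scatter). Set side by side, the two steps do not differ: the same change on two cores in this assay, a 1.8-fold lower number (0.25 log units; within the scatter) from compound 1 to compound 2 and a 1.3-fold lower number (0.12 log units; within the scatter) from compound 3 to compound 4, 1.3-fold (0.12 log units) apart, within the scatter of two such steps. The change thus reads alike on both cores, but this does not show that the added chain carbon moves the number on either core, as each step stays within the scatter, and two cores make no rule for the series.

The compounds shown leave open whether a longer chain, or another amine in place of dimethylamino, would give a step beyond the scatter. They also leave open whether the change would read the same on a third core.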